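The source may report more compounds than this note shows. Statements on the series, on what has been measured and on what is new or still open speak of the compounds shown alone.

Measured compounds in a functional assay on MOLT-4 cells (Homo sapiens) for antiproliferative activity; on this read-out lower numbers stand for stronger inhibition and higher numbers for weaker inhibition:
compound 1 `COc1cc(C(=O)c2sc(-c3ccc(Cl)c(Cl)c3)cc2N)cc(OC)c1OC` gives 270 nM
compound 2 `COc1cc(C(=O)c2sc(-c3cccc([N+](=O)[O-])c3)cc2N)cc(OC)c1OC` gives 7.5 nM
compound 3 `COc1ccc(-c2cc(N)c(C(=O)c3cc(OC)c(OC)c(OC)c3)s2)cc1OC` gives 20 nM

All three share one core and differ only in the aromatic group fixed on it. Compound 3 stands second highest of the three numbers: its nearest neighbour is reached by a 2.7-fold higher number from compound 2 to compound 3 (0.43 log units; beyond the scatter), its furthest by a 14-fold lower number from compound 1 to compound 3 (1.13 log units; beyond the scatter). Compound 4 `COc1cc(C(=O)c2sc(-c3ccccc3)cc2N)cc(OC)c1OC` is the next step from compound 3, and it differs as follows: phenyl in place of 3,4-dimethoxyphenyl on an aromatic carbon.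

Both measured steps that touch the same position bear on this change. One was large, a 14-fold lower number from compound 1 to compound 3 (1.13 log units; beyond the scatter); the other modest, a 2.7-fold higher number from compound 2 to compound 3 (0.43 log units; beyond the scatter). For the measured compounds named here, they show that the groups on this aromatic carbon shift the result strongly, but neither of them removes both substituents to leave a bare phenyl, so there is no direct precedent. The expectation is a modest step toward a higher number, though a result within the scatter cannot be ruled out. Compound 4 is therefore estimated at 50 nM, with a range from 10 nM to 250 nM. This estimate corresponds to a 2.5-fold higher number from compound 3 to compound 4 (0.40 log units; beyond the scatter).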

Compound 4, half-maximal inhibitory concentration: 5.3 nM
The estimate for compound 4 lay 9.4-fold (0.97 log units) above the measured number; the measured number lies below the stated range.
By their numbers in this assay, from the lowest: compounds 4 and 2 (each within the scatter of the next); then compound 3; then compound 1.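

In this assay the bare phenyl loses nothing: removing both methoxy groups gives a 3.8-fold lower number from compound 3 to compound 4 (0.58 log units; beyond the scatter) and removing both chlorines gives a 51-fold lower number from compound 1 to compound 4 (1.71 log units; beyond the scatter) on the same position. Removing the nitro group gives a 1.4-fold lower number from compound 2 to compound 4 (0.15 log units; within the scatter) so the bare ring and the 3-nitrophenyl group cannot be told apart, which means that among these compounds a substituent on this ring is not needed for low numbers, while compound 2 shows that one can be carried without a clear penalty. Nothing measured here explains why the substituents differ in this way.

Still open, as far as these compounds go, is how a single methoxy or a single chlorine on the ring would compare with these two-substituent rings. Also open, from the compounds shown here alone, is how an amine or a carboxylic acid on the ring would behave, or a short alkyl chain in place of the whole phenyl.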